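The source may report more compounds than this note shows. Statements on the series, on what has been measured and on what is new or still open speak of the compounds shown alone.

Measured so far:
- compound 1 `CCN1CCN(c2cc(C)c3cc(NC(=O)c4cccnc4)ccc3n2)CC1` — 26600 nM
- compound 2 `Cc1cc(NCCN2CCCCC2)nc2ccc(NC(=O)c3ccc(Cl)c(Cl)c3)cc12` — 1190 nM
- compound 3 `CCN1CCN(c2cc(C)c3cc(NC(=O)c4cccc(Br)c4)ccc3n2)CC1` — 11600 nM

In a functional assay on MCF7 cells (Homo sapiens) for antiproliferative activity, read by MTT assay, with a stated time of 72 h (a higher number here means a weaker inhibitor, a lower number a stronger inhibitor), compound 1 stands highest of the three numbers. For the measured compounds named here, the nearest is compound 3, where the step of a 2.3-fold lower number from compound 1 to compound 3 (0.36 log units; beyond the scatter) is the only single-point change measured. Going by the values given here, compound 2 lies furthest away, with a different substitution pattern on the shared core and a differently substituted ring on the carbonyl carbon; its value and that of compound 1 show the widest gap here, but no single step connects them.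

The unmeasured compound 4 `CCN1CCN(c2cc(C)c3cc(NC(=O)c4ccco4)ccc3n2)CC1` differs from compound 1 as follows: furan-2-yl in place of pyridin-3-yl on a carbonyl carbon. Among the compounds with values here, the step from compound 1 to compound 3 is the one comparison that bears on this change, since it also swaps the ring on the carbonyl carbon; it gave a modest lowering. Within the data shown here, a five-membered heteroaromatic ring entering in place of the six-membered one has no direct precedent, so the expected step is small, in the same direction as that precedent or none beyond the scatter.

Compound 4 is expected at 19000 nM (range 8000 nM to 45000 nM), a step of a 1.4-fold lower number from compound 1 to compound 4 (0.15 log units; within the scatter) estimated from the precedent of compound 3.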

Compound 4, half-maximal inhibitory concentration: 41200 nM
For compound 4 the middle estimate is 2.2-fold (0.34 log units) below the measured one; measured number inside the range.
By their numbers in this assay, from the lowest: compound 2; then compound 3; then compounds 1 and 4 (each within the scatter of the next).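

In this assay, the change to furan-2-yl in place of pyridin-3-yl on the carbonyl carbon gives a 1.5-fold higher number from compound 1 to compound 4 (0.19 log units; within the scatter), so these two rings, each aromatic with 1 hetero atom, are not told apart at this position. The 3-bromophenyl group stands apart from both: a 3.6-fold higher number from compound 3 to compound 4 (0.55 log units; beyond the scatter) joins a 2.3-fold lower number from compound 1 to compound 3 (0.36 log units; beyond the scatter), and among these three rings on the shared core, the lower number belongs to 3-bromophenyl alone. Nothing available explains this difference.

An unsubstituted phenyl ring on this carbonyl carbon would show whether the separation goes with the bromine or with the carbocyclic ring itself. On these data alone, it also remains open where a thiophen-2-yl ring would fall, and whether the same ordering of rings holds with the side chain of compound 2.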